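The source may report more compounds than this note shows. Statements on the series, on what has been measured and on what is new or still open speak of the compounds shown alone.

Compound 1 `COC1=C(OC)[C@H](O)[C@H](C/C=C(\C)CC/C=C(\C)C[C@@H]2C[C@@H](C)C(=O)O2)[C@@H](C)C1=O`; in a functional assay on A549 cells (Homo sapiens) for inhibition, read by sulforhodamine B assay, with a stated time of 48 h (on this read-out lower numbers stand for stronger inhibition of growth and higher numbers for weaker inhibition of growth), compound 1 gives 14100 nM.
Compound 2 `COC1=C(OC)[C@H](O)[C@H](C/C=C(\C)CC/C=C(\C)C[C@H](O)/C=C(\C)CO)[C@@H](C)C1=O`; in this assay compound 2 gives 12000 nM.

Going by the values given here, compound 2 carries the lowest of the two numbers so far, but its nearest neighbour is compound 1, and the step of a 1.2-fold lower number from compound 1 to compound 2 (0.07 log units; within the scatter) is within the scatter, so the two cannot be told apart on this read-out.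

Compound 3 `COC1=C(OC)[C@H](O)[C@H](C/C=C(\C)CC/C=C(\C)CCC=C(C)C)[C@@H](C)C1=O` has not yet been measured in this assay. It differs from compound 2 in one place: a group of 5 heavy atoms (5 carbon; no ring) in place of a group of 7 heavy atoms (5 carbon, 2 oxygen; no ring), on a saturated chain carbon bound to a double-bonded chain carbon. The entering 3-methylbut-2-en-1-yl group sits on a saturated chain carbon bound to a double-bonded chain carbon, the same place at which compound 1 and compound 2 differ.

Among the compounds with values here, only one measured step bears on this position, the one from compound 1 to compound 2, and it was small: a 1.2-fold lower number from compound 1 to compound 2 (0.07 log units; within the scatter). That exchange at the chain end left the number essentially where it was. On this single precedent, a change at the same place is expected to give a step of a 1.1-fold higher number from compound 2 to compound 3 (0.03 log units; within the scatter) that stays within the scatter. Compound 3 is therefore estimated at 13000 nM, with a range from 6000 nM to 30000 nM.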

Compound 3, concentration for 50% growth inhibition: 5700 nM
Beside the measured number, compound 3's estimate is 2.3-fold (0.36 log units) above it, outside the stated range (below it).
By their numbers in this assay, from the lowest: compound 3; then compounds 2 and 1 (each within the scatter of the next).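

In this assay this position proves not to be indifferent to what it carries: exchanging the group of 7 heavy atoms, with its 2 hydrogen-bond donors and 2 hydrogen-bond acceptors, for the 3-methylbut-2-en-1-yl group, which has neither, gives a 2.1-fold lower number from compound 2 to compound 3 (0.32 log units; beyond the scatter), a modest step beyond the scatter. The exchange of the ring-bearing group at the same saturated chain carbon bound to a double-bonded chain carbon runs the same way, with a 2.5-fold lower number from compound 1 to compound 3 (0.39 log units; beyond the scatter), so the two oxygen-bearing groups that could not be told apart earlier both give weaker inhibition of growth than the 3-methylbut-2-en-1-yl group. No measurement offered here accounts for this difference.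

In the step to compound 3 the oxygen atoms, the hydrogen-bond donors and the defined stereocentre of the leaving group all go at once, so the compounds shown do not tell which of these matters. They also leave open how an amine or a carboxylic acid at this place would read, and whether a longer chain ending in the 3-methylbut-2-en-1-yl group would extend the step or reverse it.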